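Replacing the tetrazolyl cyclohexyl group of compound 3

The source may report more compounds than this note shows. Statements on the series, on what has been measured and on what is new or still open speak of the compounds shown alone.

Measured in an ADME assay on microsomes from liver (Mus musculus) for metabolic stability, with a stated time of 10 min; on this read-out lower numbers stand for a less stable compound and higher numbers for a more stable compound:
- compound 1 `C[C@]1(C(=O)N2CC[C@](c3ccc(C(F)(C(F)(F)F)C(F)(F)F)cc3)(S(=O)(=O)c3ccc(F)cc3)C2)CC[C@H](C(=O)O)CC1` gives 95%
- compound 2 `COC[C@]1(C(=O)N2CC[C@](c3ccc(C(F)(C(F)(F)F)C(F)(F)F)cc3)(S(=O)(=O)c3ccc(F)cc3)C2)CC[C@H](C(=O)O)CC1` gives 88%
- compound 3 `O=C([C@H]1CC[C@H](c2nnn[nH]2)CC1)N1CC[C@](c2ccc(C(F)(C(F)(F)F)C(F)(F)F)cc2)(S(=O)(=O)c2ccc(F)cc2)C1` gives 73%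

Compound 3, at 73%, stands lowest of the three, beyond the scatter from both others. Compound 4 `CCC1(C(=O)N2CC[C@](c3ccc(C(F)(C(F)(F)F)C(F)(F)F)cc3)(S(=O)(=O)c3ccc(F)cc3)C2)CCS(=O)(=O)CC1` differs from it in one place: 4-ethyl-1,1-dioxothian-4-yl in place of 4-(1H-tetrazol-5-yl)cyclohexyl on a carbonyl carbon. In words, this is 4-ethyl-1,1-dioxothian-4-yl in place of 4-(1H-tetrazol-5-yl)cyclohexyl on a carbonyl carbon.

Two measured steps change this same place, and both are modest: a number 22 percentage points lower from compound 1 to compound 3 (beyond the scatter), and a number 15 percentage points lower from compound 2 to compound 3 (beyond the scatter). Both end at the group that now leaves, so read backwards they point upward. The remaining step, a number 7 percentage points lower from compound 1 to compound 2 (within the scatter), shows that the two carboxy-bearing groups are not told apart here. Going by the values given here, no measured compound carries the entering group, and no measured step shows what it does, so these steps give only a rough size and a tentative direction.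

A small rise, not clearly beyond the scatter, is expected: the estimated step is a number 8 percentage points higher from compound 3 to compound 4 (within the scatter). The estimate for compound 4 is 81%, with an expected range from 62% to 94%.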

Compound 4, percent of the compound remaining: 0%
Estimate against measurement, compound 4: 81 percentage points above; measured number outside the range, below it.
By their numbers in this assay, from the lowest: compound 4; then compound 3; then compounds 2 and 1 (each within the scatter of the next).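

At this position, on the carbonyl carbon bound to the amide-type nitrogen in a ring, the earlier exchanges moved stability only modestly, whereas in this assay the new exchange gives a large loss (a number 73 percentage points lower from compound 3 to compound 4 (beyond the scatter)). The loss is also large against both carboxy-bearing compounds (a number 88 percentage points lower from compound 2 to compound 4 (beyond the scatter); a number 95 percentage points lower from compound 1 to compound 4 (beyond the scatter)), so 4-ethyl-1,1-dioxothian-4-yl stands well apart from all three groups measured earlier, and the steps among those groups now look small by comparison. Nothing measured here accounts for this drop.

Because 4-ethyl-1,1-dioxothian-4-yl differs from the groups it replaces in both its ring and its substituents, the compounds shown do not separate the contribution of the 1,1-dioxo unit from that of the ethyl group, nor show whether the tetrazole or carboxylic acid must be present at all. A hydroxyl or a primary amide on the cyclohexyl ring, or a methyl in place of the ethyl on the 1,1-dioxothiane ring, would be needed to tell how much of the large loss belongs to each of these features.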